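Removing a Benzyl Group from a Sulfamate Series

This account rests on a few compounds, and the source may have more. Where it says the series, first, only, none or still open, it means among the compounds named here.

Of the compounds shown here, three sharing one core have been measured in an assay on HEK293 cells for inhibition of Steryl-sulfatase (Homo sapiens), tested at 0.1 uM; a lower number here means a weaker effect, a higher number a stronger effect of the compound at the concentration tested. Compound 1 `NS(=O)(=O)Oc1ccc2c(c1)CN(C(=O)c1cccc(N3CCC(Cc4ccccc4)CC3)c1)CC2` gives 1.4% in this assay. Compound 2 `CN(C)CCN(CCN(C)C)c1ccc(C(=O)N2CCc3ccc(OS(N)(=O)=O)cc3C2)cc1` gives 3.8%, and compound 3 `NS(=O)(=O)Oc1ccc2c(c1)CN(C(=O)c1cccc(N3CCN(c4ncccn4)CC3)c1)CC2` gives 1.6%. The three numbers all lie within the usual scatter of each other, so compound 1 cannot be told apart from compound 2 or compound 3 on these data; all three show only a weak effect at the tested concentration.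

Compound 4 `NS(=O)(=O)Oc1ccc2c(c1)CN(C(=O)c1cccc(N3CCCCC3)c1)CC2` has not yet been measured. It differs from compound 1 in one place: hydrogen in place of benzyl on a saturated ring carbon. Among the compounds with values here, with no measured step of this kind to lean on, and with every number so far sitting in the same low band, the step from compound 1 to compound 4 is expected to be no larger than the scatter, in no particular direction, and is estimated as a number 0.6 percentage points higher from compound 1 to compound 4 (within the scatter). For compound 4 the value in this assay is therefore estimated at 2%, within a range from -5% to 10%.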

Compound 4, a percentage reported as inhibition, at one concentration (the size of the read-out at that concentration, not a potency): 1%
For compound 4 the middle estimate is 1 percentage points above the measured one, within the range that was stated.
By their numbers in this assay, from the lowest: compounds 4, 1, 3 and 2 (each within the scatter of the next).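

Within the data shown here, putting hydrogen in place of benzyl on this saturated ring carbon gives the first comparison that differs in only one place: in this assay the step is a number 0.4 percentage points lower from compound 1 to compound 4 (within the scatter) and so cannot be told apart from repeat-measurement noise. Even the loss of the whole benzyl group, with its aromatic ring, therefore produces no detectable change at this position, although both compounds give so little effect at the tested concentration that this is a limited test. No available measurement offers an explanation for this result.

The compounds shown leave open whether an amine, a carboxylic acid or a longer chain on this ring carbon would give a read-out beyond the scatter. They also leave open whether compound 1 and compound 4 would differ at a higher concentration, where the effect might be larger.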